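Same atoms rearranged: compound 4 against compound 1

The compounds below may be only part of what the source reports. "The series", "measured", "known", "first", "only" and "open" are said of these compounds alone.

In an ADME assay on cells (Homo sapiens) for cytotoxicity, read by polymerase chain reaction, with a stated time of 3 days (on this read-out higher numbers stand for lower toxicity in this test and lower numbers for higher toxicity in this test), compound 1 `CCCc1nccc2sc(-c3c(C)nc(N[C@H](C)c4ccc(OC(F)(F)F)cc4)nc3N[C@@H]3C[C@H](CO)[C@@H](O)[C@H]3O)nc12` gives 13000 nM, compound 2 `Cc1nc(N[C@H](C)c2ccc(OC(F)(F)F)cc2)nc(N[C@@H]2C[C@H](CO)[C@@H](O)[C@H]2O)c1-c1nc2c(C3CCC3)nccc2s1` gives 5000 nM and compound 3 `COC(=O)CCc1nccc2sc(-c3c(C)nc(N[C@H](C)c4ccc(OC(F)(F)F)cc4)nc3N[C@@H]3C[C@H](CO)[C@@H](O)[C@H]3O)nc12` gives 23000 nM. Compound 1 thus stands within the scatter of compound 3 and outside it from compound 2. Compound 4 `CCc1nc(C)cc2sc(-c3c(C)nc(N[C@H](C)c4ccc(OC(F)(F)F)cc4)nc3N[C@@H]3C[C@H](CO)[C@@H](O)[C@H]3O)nc12` carries a group of 12 heavy atoms (9 carbon, 2 nitrogen, 1 sulfur; one five-membered aromatic ring with 2 hetero atoms, one six-membered aromatic ring with 1 hetero atom) in place of a group of 12 heavy atoms (9 carbon, 2 nitrogen, 1 sulfur; one five-membered aromatic ring with 2 hetero atoms, one six-membered aromatic ring with 1 hetero atom), on an aromatic carbon, on an aromatic carbon of a six-membered aromatic ring with 2 nitrogen. The two have the same atoms, joined differently. The closest measured changes lie within that same group: a 2.6-fold lower number from compound 1 to compound 2 (0.41 log units; beyond the scatter), which is modest, and a 1.8-fold higher number from compound 1 to compound 3 (0.25 log units; within the scatter), which stays within the scatter. Neither matches this change, so no step beyond the scatter is expected in this assay, and no direction is favoured. The expected step is a 1.1-fold lower number from compound 1 to compound 4 (0.03 log units; within the scatter). For compound 4 the estimated value is 12000 nM, with an expected range of 5500 nM to 26000 nM.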

Compound 4, half-maximal cytotoxic concentration: 23000 nM
The estimate for compound 4 lay 1.9-fold (0.28 log units) below the measured number, within the range that was stated.
By their numbers in this assay, from the lowest: compound 2; then compounds 1, 3 and 4 (each within the scatter of the next).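

In this assay, joining the same atoms differently within the group on this aromatic carbon gives a 1.8-fold higher number from compound 1 to compound 4 (0.25 log units; within the scatter), so this rearrangement produces no step beyond the scatter. The earlier compounds shown here changed the atoms of the group, and only the cyclobutyl change gave a step beyond the scatter, a 2.6-fold lower number from compound 1 to compound 2 (0.41 log units; beyond the scatter). No measurement available here accounts for this result. On these data alone, whether a carboxylic acid or an amine within this group would give a step beyond the scatter remains open.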